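Replacing the sec-butyl side chain of compound 1 with 2-carbamoylethyl

The compounds below may be only part of what the source reports. "The series", "measured", "known", "first", "only" and "open" are said of these compounds alone.

The study compares three measured acids and esters built on a shared core, and one compound that has not yet been tested. Compound 1 `CC[C@H](C)[C@H](NC(=O)CN(c1nc(Cl)nc2[nH]cnc12)C1CC1)C(=O)O` gives 30.3% in a functional assay on the whole organism (Tail, strain ICR) with Mus musculus as the target, in the tail flick test, with a stated time of 30 min, at a dose of 25 umol/kg by the oral route (a lower number here means a weaker effect, a higher number a stronger effect of the compound at the dose given), which places it second highest of the three measured numbers. Compound 2 `NCCCC[C@H](NC(=O)CN(c1nc(Cl)nc2[nH]cnc12)C1CC1)C(=O)OCc1ccccc1` gives 26.1% in this assay, a value within the scatter of compound 1. Compound 3 `CC[C@H](C)[C@H](NC(=O)CN(c1nc(Cl)nc2[nH]cnc12)C1CC1)C(=O)OCc1ccccc1` gives 41.4% in this assay, and the change of benzyl in place of hydrogen on an oxygen next to a carbonyl group brought a number 11.1 percentage points higher from compound 1 to compound 3 (beyond the scatter).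

Compound 4 `NC(=O)CC[C@H](NC(=O)CN(c1nc(Cl)nc2[nH]cnc12)C1CC1)C(=O)O` differs from compound 1 at one place: 2-carbamoylethyl in place of sec-butyl on a saturated chain carbon bound to an amide-type nitrogen and a carbonyl carbon. The measured step that bears on this is the replacement of 4-aminobutyl by sec-butyl, which gave a number 15.3 percentage points higher from compound 2 to compound 3 (beyond the scatter). Compound 4 moves in the opposite direction, away from sec-butyl toward a side chain carrying one hydrogen-bond donor and one hydrogen-bond acceptor, so a modest decrease is expected. Among the compounds with values here, because the only relevant precedent is a number 15.3 percentage points higher from compound 2 to compound 3 (beyond the scatter), the expected step from compound 1 to compound 4 is a number 9.3 percentage points lower from compound 1 to compound 4 (within the scatter). Compound 4 is therefore estimated at 21% in this assay, within the range 8% to 34%.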

Compound 4, a percentage reported as activity, at one dose (the size of the read-out at that dose, not a potency): 33.1%
Compound 4: the middle estimate sits 12.1 percentage points below what was measured; the range from low to high includes it.
By their numbers in this assay, from the lowest: compounds 2, 1, 4 and 3 (each within the scatter of the next, the first and the last beyond it).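

In this assay, 2-carbamoylethyl in place of sec-butyl on the free acid gave a number 2.8 percentage points higher from compound 1 to compound 4 (within the scatter), so the read-out does not separate these two side chains at this position. Within the data shown here, the only earlier side-chain step at this position, a number 15.3 percentage points higher from compound 2 to compound 3 (beyond the scatter), came from a pair of benzyl esters, so compound 4 adds the first such step on the free acid and shows that a change of side chain here need not go beyond the scatter. Nothing in the material shown accounts for this result.

The compounds shown leave open how 2-carbamoylethyl behaves on the benzyl ester, the form in which the sec-butyl series gave a number 11.1 percentage points higher from compound 1 to compound 3 (beyond the scatter) when benzyl replaced hydrogen on the oxygen. They also leave open whether the free acid would keep the same read-out with a side chain ending in a carboxylic acid or an amine, or with a shorter chain such as methyl.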